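The source may report more compounds than this note shows. Statements on the series, on what has been measured and on what is new or still open speak of the compounds shown alone.

Compound 1 `CN(C(=O)c1ccccc1)c1ccc2[nH]c(-c3n[nH]c4ccccc34)cc2n1` carries a benzoyl group on the amide nitrogen that hangs from its shared core. In a functional assay on HCT-116 cells (Homo sapiens) for antiproliferative activity, read by MTT assay, with a stated time of 72 h (on this read-out higher numbers stand for weaker inhibition and lower numbers for stronger inhibition), compound 1 gives 10600 nM. Two measured relatives differ from it only on that phenyl ring. Compound 2 `CN(C(=O)c1ccc(Br)cc1)c1ccc2[nH]c(-c3n[nH]c4ccccc34)cc2n1` gives 6110 nM, a step of a 1.7-fold lower number from compound 1 to compound 2 (0.24 log units; within the scatter). Compound 3 `COc1ccc(C(=O)N(C)c2ccc3[nH]c(-c4n[nH]c5ccccc45)cc3n2)cc1` gives 29500 nM, a step of a 2.8-fold higher number from compound 1 to compound 3 (0.44 log units; beyond the scatter). Compound 1 therefore sits close to compound 2 and apart from compound 3 only, as a 4.8-fold higher number from compound 2 to compound 3 (0.68 log units; beyond the scatter) also shows.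

Compound 4 `CN(C(=O)c1ccco1)c1ccc2[nH]c(-c3n[nH]c4ccccc34)cc2n1` is not yet measured. It differs from compound 1 in furan-2-yl in place of phenyl on a carbonyl carbon. Among the measured compounds shown here, no measured step exchanges the ring itself; the two known steps only decorate the phenyl that leaves, and both stay modest. So the exchange of the whole ring is expected to move the number by no more than a modest amount in either direction, most likely within the scatter. For compound 4 the expected step is a 1.1-fold higher number from compound 1 to compound 4 (0.05 log units; within the scatter). Compound 4 is therefore estimated at 12000 nM, between 5000 nM and 30000 nM.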

Compound 4, half-maximal inhibitory concentration: 30000 nM
Compound 4: middle estimate off by 2.5-fold (0.40 log units), on the low side, within the range that was stated.
By their numbers in this assay, from the lowest: compounds 2 and 1 (each within the scatter of the next); then compounds 3 and 4 (each within the scatter of the next).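

With a 2.8-fold higher number from compound 1 to compound 4 (0.45 log units; beyond the scatter) in this assay the exchange of the whole ring shows that this position responds to the ring itself, not only to what is attached to the phenyl. Furan-2-yl and 4-methoxyphenyl cannot be told apart here, as a 1.0-fold higher number from compound 3 to compound 4 (0.01 log units; within the scatter) shows, so two quite different groups on the carbonyl carbon end up at the same level. The 4-bromophenyl group stands clearly apart from furan-2-yl, as a 4.9-fold higher number from compound 2 to compound 4 (0.69 log units; beyond the scatter) shows.

Nothing among the data shown accounts for this shift. From the compounds shown here alone, it stays open whether a pyridine ring, a thiophene ring or a plain alkyl chain on the carbonyl carbon would fall with compound 2 or with compound 3, and whether a ring is needed there at all.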